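This account rests on a few compounds, and the source may have more. Where it says the series, first, only, none or still open, it means among the compounds named here.

Series notes. In an in vitro assay on COS-1 cells for inhibition of sodium-dependent dopamine transporter (Homo sapiens) (on this read-out lower numbers stand for stronger inhibition and higher numbers for weaker inhibition), compound 1 `COC(=O)C1=C(c2ccccc2)C2CCC1C2` gives 646000 nM. Compound 2 `COC(=O)C1=C(c2cccc(Cl)c2)C2CCC1C2` gives 105000 nM in this assay, and compound 3 `COC(=O)C1=C(c2ccccc2Cl)C2CCC1C2` gives 372000 nM. Compound 3 thus holds the second highest of the three numbers; its gap to compound 1 is within the scatter, its gap to compound 2 beyond it. Both measured steps, a 1.7-fold lower number from compound 1 to compound 3 (0.24 log units; within the scatter) and a 6.2-fold lower number from compound 1 to compound 2 (0.79 log units; beyond the scatter), put chloro in place of hydrogen on an aromatic carbon. Compound 4 `COC(=O)C1=C(c2cccc(Cl)c2Cl)C2CCC1C2` differs from compound 3 by chloro in place of hydrogen on an aromatic carbon. The step that bears most on this change is a 6.2-fold lower number from compound 1 to compound 2 (0.79 log units; beyond the scatter), a modest one, so a downward step of about that size is expected in this assay, namely a 5.3-fold lower number from compound 3 to compound 4 (0.73 log units; beyond the scatter). Compound 4 is therefore estimated at 70000 nM, expected between 25000 nM and 200000 nM.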

Compound 4, inhibition constant: 14800 nM
The estimate for compound 4 lay 4.7-fold (0.67 log units) above the measured number, outside the stated range (below it).
By their numbers in this assay, from the lowest: compound 4; then compound 2; then compounds 3 and 1 (each within the scatter of the next).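

Chloro in place of hydrogen on this aromatic carbon, ortho to a chloro group, gives a 25-fold lower number from compound 3 to compound 4 (1.40 log units; beyond the scatter) in this assay, so the size of this change depends on the core that carries it: the same change on two cores in this assay, a 6.2-fold lower number (0.79 log units; beyond the scatter) from compound 1 to compound 2 and a 25-fold lower number (1.40 log units; beyond the scatter) from compound 3 to compound 4, 4.1-fold (0.61 log units) apart, beyond the scatter of two such steps. The other chloro of compound 4 shows the same dependence, with a 7.1-fold lower number from compound 2 to compound 4 (0.85 log units; beyond the scatter) on the core that already carries a chloro: the same change on two cores in this assay, a 1.7-fold lower number (0.24 log units; within the scatter) from compound 1 to compound 3 and a 7.1-fold lower number (0.85 log units; beyond the scatter) from compound 2 to compound 4, 4.1-fold (0.61 log units) apart, beyond the scatter of two such steps. The compounds shown leave open whether a methyl, a methoxy or an amine at this place would give a step of similar size. Also open, from the compounds shown here alone, is whether the step persists with a carboxylic acid or an amide in place of the methyl ester.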